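Hydroxypiperidine in place of difluoropiperidine on the pyrimidine-side ring carbon

A few compounds are considered here, and "the series" means these few. Any claim that something is new, unique, unknown or untested is made for them only; others in the source may bear on it.

For the measured compounds named here, in an assay on a protein complex for activation of soluble guanylate cyclase (Homo sapiens), read by cGMP accumulation, in the presence of a further agent that is not named here (a lower number here means that less compound is needed, a higher number that more compound is needed for the effect), compound 3 `Fc1ccccc1Cn1nc(-c2ncc(F)c(N3CCC(F)(F)CC3)n2)cc1-c1ccon1` gives 250 nM, the second highest of the three numbers measured so far. Compound 1 `Fc1ccccc1Cn1nc(-c2ncc(F)c(OCC3CC3)n2)cc1-c1ccon1` gives 2300 nM, and compound 2 `CNc1nc(-c2cc(-c3ccon3)n(Cc3ccccc3F)n2)ncc1F` gives 20 nM. The measured steps run a 120-fold lower number from compound 1 to compound 2 (2.06 log units; beyond the scatter), a 9.2-fold lower number from compound 1 to compound 3 (0.96 log units; beyond the scatter) and a 13-fold higher number from compound 2 to compound 3 (1.10 log units; beyond the scatter).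

Compound 4 `OC1CCN(c2nc(-c3cc(-c4ccon4)n(Cc4ccccc4F)n3)ncc2F)CC1` is not yet measured. It differs from compound 3 in one place: 4-hydroxypiperidin-1-yl in place of 4,4-difluoropiperidin-1-yl on an aromatic carbon The six-membered non-aromatic ring with one hetero atom stays on the same aromatic carbon; the two fluorine leave and a hydroxy group arrives.

Both steps into compound 3, a 9.2-fold lower number from compound 1 to compound 3 (0.96 log units; beyond the scatter) and a 13-fold higher number from compound 2 to compound 3 (1.10 log units; beyond the scatter), show that this carbon accepts groups of different kinds, with the methylamino of compound 2 giving the lowest number and the difluoropiperidine standing between. Going by the values given here, no measured step swaps one piperidine for another, so the size of this change is not anchored. The expected step is a 1.7-fold lower number from compound 3 to compound 4 (0.22 log units; within the scatter), a modest move toward a lower number that could still fall within the scatter. Compound 4 is therefore estimated at 150 nM, with a range from 40 nM to 600 nM.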

Compound 4, half-maximal effective concentration: 10 nM
Compound 4: the middle estimate sits 15-fold (1.18 log units) above what was measured; the whole stated range lies above it.
By their numbers in this assay, from the lowest: compounds 4 and 2 (each within the scatter of the next); then compound 3; then compound 1.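

In this assay, the group carried by the piperidine ring, and not the ring alone, decides the number at this aromatic carbon: 4-hydroxypiperidin-1-yl in place of 4,4-difluoropiperidin-1-yl gives a large step (a 25-fold lower number from compound 3 to compound 4 (1.40 log units; beyond the scatter)). For the compounds shown here, compound 4 and compound 2 cannot be told apart (a 2.0-fold lower number from compound 2 to compound 4 (0.30 log units; within the scatter)), so a piperidine on this carbon can do as well as methylamino, which the earlier compounds did not show. Going by these compounds alone, the step from cyclopropylmethoxy (a 230-fold lower number from compound 1 to compound 4 (2.36 log units; beyond the scatter)) lies beyond the scatter, as does the one from compound 1 to compound 2.

Nothing available bears on what lies behind the difference between the hydroxy group and the two fluorine. Open too, going by these compounds, is whether a methoxy group, an amino group or a carboxylic acid in place of that hydroxy group would keep the number this low.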